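Shortening the side chain on a triazene amide series

The source may hold more compounds than are shown below. What is called first, only, known or untested is meant among the compounds shown, and "the series" means these compounds.

Among the compounds with values here, the two compounds measured so far share a core and differ in the side chain on the carbon between the amide nitrogen and the carbonyl and in the acyl group on the nitrogen. Compound 1, `CCC(=O)N[C@@H](C)C(=O)N(C)/N=N/c1ccc(C#N)cc1`, gives 1.87 in a physicochemical assay for lipophilicity, read by HPLC, in phosphate buffer, measured as octanol-water partition, at pH 7.4; on this read-out higher numbers stand for higher lipophilicity and lower numbers for lower lipophilicity. Compound 2, `CC(=O)N[C@H](C(=O)N(C)/N=N/c1ccc(C#N)cc1)C(C)C`, gives 2.18 in this assay, and this is the higher of the two numbers, standing above compound 1 by a gap that lies beyond the scatter of the method.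

Compound 3, `CC(=O)NCC(=O)N(C)/N=N/c1ccc(C#N)cc1`, has not yet been measured. Relative to compound 2 the change is hydrogen in place of isopropyl on a saturated chain carbon bound to an amide-type nitrogen and a carbonyl carbon; in other words, the isopropyl group is simply removed from the chain carbon that carries the amide nitrogen and the carbonyl carbon.

Since the loss of an isopropyl takes away three carbon atoms, compound 3 is expected to give a clearly lower number than compound 2, with a step of a number 0.98 log units lower from compound 2 to compound 3 (beyond the scatter) in this assay. Compound 3 is therefore estimated at 1.2, within a range from 0.8 to 1.6.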

Compound 3, partition coefficient: 1.1
Compound 3: middle estimate off by 0.10 log units, on the high side; the range from low to high includes it.
By their numbers in this assay, from the lowest: compound 3; then compound 1; then compound 2.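

In this assay, hydrogen in place of isopropyl on a saturated chain carbon bound to an amide-type nitrogen and a carbonyl carbon gives a number 1.08 log units lower from compound 2 to compound 3 (beyond the scatter), a large step that isolates this one change at this position, which the earlier pair of compounds could not do. The second comparison, a group of 5 heavy atoms in place of a group of 7 heavy atoms on a carbonyl carbon, gives a number 0.77 log units lower from compound 1 to compound 3 (beyond the scatter), a modest step that leaves compound 3 the lowest of the three, with its steps to both others printed as beyond the scatter. Nothing measured in this account gives a reason for either step.

From the compounds shown here alone, what a longer chain, an amine or a carboxylic acid on this same chain carbon would read in this assay remains open, as does the place such groups would take among the three numbers. Also open, going by these compounds, is whether hydrogen in place of isopropyl would give a step of similar size with a different group on the carbonyl carbon, since this change is seen in a single pair.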